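The source may report more compounds than this note shows. Statements on the series, on what has been measured and on what is new or still open speak of the compounds shown alone.

Measured compounds:
- compound 1, `CC(=O)O[C@H]1CC[C@]2(C)[C@H](CC[C@@](C)(O)[C@H]2CC[C@@H]2C(C)=CC[C@H]3[C@H](CC[C@]3(C)O)C2(C)C)OC1(C)C`: 47900 nM
- compound 2, `CC(=O)O[C@H]1CC[C@]2(C)[C@H](CC[C@@](C)(O)[C@H]2CC[C@@H]2C(C)=CC[C@H]3[C@H](CC[C@]3(C)OC(C)=O)C2(C)C)OC1(C)C`: 39200 nM
- compound 3, `CC1=CC[C@H]2[C@@H]1CC=C(C)[C@@H](CC[C@H]1[C@]3(C)CC[C@H](OCc4ccccc4)C(C)(C)O[C@H]3CC[C@@]1(C)O)C2(C)C`: > 50000 nM, a limit of the assay rather than a number

All values come from a functional assay on MCF7 cells (Homo sapiens) for antiproliferative activity, read by MTT assay, with a stated time of 72 h; on this read-out lower numbers stand for stronger inhibition and higher numbers for weaker inhibition. Compound 1 stands highest of the two numbers; its nearest neighbour is compound 2, and the step of a 1.2-fold lower number from compound 1 to compound 2 (0.09 log units; within the scatter) stays within the scatter. Compound 3 sits at the limit of > 50000 nM in this assay, at which 1 of the 3 values shown sits, so its reading says only that it is a limit.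

Compound 4, `CC1=CC[C@H]2[C@H](CC[C@]2(C)O)C(C)(C)[C@@H]1CC[C@H]1[C@]2(C)CC[C@H](OC(=O)c3cccc(C(F)(F)F)c3)C(C)(C)O[C@H]2CC[C@@]1(C)O`, differs from compound 1 in one place: 3-(trifluoromethyl)phenyl in place of methyl on a carbonyl carbon. Going by the values given here, the only measured step, from compound 1 to compound 2, concerns an acetyl in place of hydrogen on an oxygen on a saturated carbon, not the carbonyl carbon where the new group enters, so no measured step bears directly on this change. With nothing pointing either way, no step beyond the scatter is expected in this assay.

Compound 4 is therefore estimated at 40000 nM, with a likely range from 15000 nM to 60000 nM. The expected step is a 1.2-fold lower number from compound 1 to compound 4 (0.08 log units; within the scatter).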

Compound 4, half-maximal inhibitory concentration: 37900 nM
Compound 4: the middle estimate sits 1.1-fold (0.02 log units) above what was measured; the measured number falls inside the stated range.
By their numbers in this assay, from the lowest: compounds 4, 2 and 1 (each within the scatter of the next). At a limit, above all of these: compound 3.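

Replacing the methyl with 3-(trifluoromethyl)phenyl on the carbonyl carbon in this assay gives a 1.3-fold lower number from compound 1 to compound 4 (0.10 log units; within the scatter). Going by these compounds alone, the earlier measured step concerned an acetyl on an oxygen, so this is the first reading of a change on this carbonyl carbon, and it shows that a much larger group carrying an aromatic ring leaves the number within the scatter. Nothing measured here explains why the number holds steady.

Going by these compounds, it remains open whether a plain phenyl, an amine or a chain ending in a carboxylic acid on this carbonyl carbon would shift the number. The three numbers shown lie within the scatter of one another, so these compounds reveal no change that clearly strengthens or weakens inhibition.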